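The source may report more compounds than this note shows. Statements on the series, on what has been measured and on what is new or still open speak of the compounds shown alone.

Measured so far:
- compound 1, `O=c1cc(/C=C/c2ccc(O)c(O)c2)oc2cc(O)cc(O)c12`, in a functional assay, in the presence of a further agent that is not named here (on this read-out lower numbers stand for stronger inhibition and higher numbers for weaker inhibition), compound 1 gives 630 nM
- compound 2, `O=c1cc(/C=C/c2ccc(O)c(O)c2)oc2cccc(O)c12`, in this assay compound 2 gives 510 nM

Compound 1 stands at the higher of the two numbers, but its nearest neighbour, compound 2, lies within the scatter: a 1.2-fold lower number from compound 1 to compound 2 (0.09 log units; within the scatter). Among the measured compounds shown here, the only measured step therefore shows no difference beyond the scatter for hydrogen in place of hydroxy on an aromatic carbon of the shared core.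

Compound 3, `O=c1cc(/C=C/c2ccc(O)cc2)oc2cc(O)cc(O)c12`, has not yet been measured. It differs from compound 1 by hydrogen in place of hydroxy on an aromatic carbon. For the measured compounds named here, the place is different from the one probed by compound 2: here the hydroxy that leaves sits on the six-membered aromatic ring of carbon only that carries the double bond, ortho to a hydroxy group and meta to a large group. The step from compound 1 to compound 2 bears on it only loosely, since it concerns a different ring, and it was within the scatter. Going by the values given here, no measured step tests a change at this place.

For compound 3 the account therefore expects a step of a 1.6-fold higher number from compound 1 to compound 3 (0.20 log units; within the scatter) in this assay, that is a number somewhat higher than that of compound 1, but with wide uncertainty. The estimate for compound 3 in this assay is 1000 nM, with a range from 400 nM to 2500 nM.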

Compound 3, half-maximal inhibitory concentration: 1210 nM
Beside the measured number, compound 3's estimate is 1.2-fold (0.08 log units) below it; low and high end bracket the measured number.
By their numbers in this assay, from the lowest: compounds 2, 1 and 3 (each within the scatter of the next, the first and the last beyond it).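

In this assay the hydroxy on the six-membered aromatic ring of carbon only, ortho to a hydroxy group and meta to a large group, gives way to hydrogen with a 1.9-fold higher number from compound 1 to compound 3 (0.28 log units; within the scatter) and so, at this newly tested place, the exchange stays within the scatter. Hydroxy has now been replaced by hydrogen at two separate places on compound 1, the other being the step with a 1.2-fold lower number from compound 1 to compound 2 (0.09 log units; within the scatter) and neither step shows that the hydroxy concerned is needed for the number in this assay. No independent measurement bears on this result, and what lies behind it stays unexplained.

The compounds shown leave open what a methoxy group, a fluorine atom, an amine or a carboxylic acid would give at this place, since hydrogen is the only replacement shown here. They also leave open whether the remaining hydroxy on this ring can be replaced by hydrogen as well, and whether replacing hydroxy at both tested places together would still stay within the scatter of compound 1.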